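The source may report more compounds than this note shows. Statements on the series, on what has been measured and on what is new or still open speak of the compounds shown alone.

Compound 2 `Cc1nc(N)c2c(-c3cc4ccccc4o3)cn([C@@H]3O[C@H](CO)[C@@H](O)[C@H]3O)c2n1` bears a 1-benzofuran-2-yl group, and in a functional assay on K562 cells (Homo sapiens), read by MTT assay, with a stated time of 72 h (on this read-out lower numbers stand for stronger inhibition and higher numbers for weaker inhibition), compound 2 gives 4990 nM. Compound 1 `Cc1nc(N)c2c(-c3ccco3)cn([C@@H]3O[C@H](CO)[C@@H](O)[C@H]3O)c2n1` differs from it in one place: furan-2-yl in place of 1-benzofuran-2-yl on an aromatic carbon. For compound 1 this assay reports only a limit, > 20000 nM. That exchange gave an at least 4.0-fold higher number from compound 2 to compound 1 (0.60 log units; beyond the scatter), a move toward weaker inhibition. Compound 3 `CNc1ncnc2c1c(-c1cc3ccccc3o1)cn2[C@@H]1O[C@H](CO)[C@@H](O)[C@H]1O` has the same atoms as compound 2 joined differently; the difference between the two cores is not broken down here. For compound 3 this assay likewise reports only a limit, > 20000 nM. Compound 4 `CNc1ncnc2c1c(-c1ccco1)cn2[C@@H]1O[C@H](CO)[C@@H](O)[C@H]1O` is not yet measured and differs from compound 3 by furan-2-yl in place of 1-benzofuran-2-yl on an aromatic carbon, the same change at the same place as before. Because compound 3 already sits at the limit of > 20000 nM in this assay, at which 2 of the 3 values shown sit, and the earlier step of an at least 4.0-fold higher number from compound 2 to compound 1 (0.60 log units; beyond the scatter) ran toward weaker inhibition, compound 4 is expected to remain at a limit, its expected step being a step that the limit leaves unreadable from compound 3 to compound 4. The estimate for compound 4 is 50000 nM, expected to fall between 20000 nM and 200000 nM.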

Compound 4, half-maximal inhibitory concentration: 15100 nM
The estimate for compound 4 lay 3.3-fold (0.52 log units) above the measured number, and the stated range ends above it.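

In this assay, furan-2-yl in place of 1-benzofuran-2-yl on the core of compound 3 gave an at least 1.3-fold lower number from compound 3 to compound 4 (0.12 log units; that floor lies within the scatter). Set beside the earlier step, the same exchange did not carry over unchanged from one core to the other: the same change on two cores in this assay, an at least 4.0-fold higher number (0.60 log units; beyond the scatter) from compound 2 to compound 1 and an at least 1.3-fold lower number (0.12 log units; that floor lies within the scatter) from compound 3 to compound 4, at least 5.3-fold (0.72 log units) apart, beyond the scatter of two such steps This shows that the two cores responded differently to this one exchange, but it does not give the true size of either step or a rule for the series, and each step rests on a limit: the limit of > 20000 nM in this assay, at which 2 of the 4 values shown sit.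

The compounds shown leave open how either core would respond to a phenyl or thiophen-2-yl group on the same aromatic carbon. They also leave open whether a longer chain on the amine would change the picture.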